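Swapping the Ring on the Amine-Linked Arm of Compound 1

The source may report more compounds than this note shows. Statements on the series, on what has been measured and on what is new or still open speak of the compounds shown alone.

The measured compounds:
- compound 1 `Cn1cc(CN2CCC[C@H](OCc3cc(Cl)cc(Cl)c3)[C@@H]2c2ccccc2)cn1` — 110000 nM
- compound 2 `COC(=O)Nn1c(C[C@H]2CCC[C@H](OCc3cc(C(F)(F)F)cc(C(F)(F)F)c3)[C@@H]2c2ccccc2)n[nH]c1=O` — 4500 nM
- compound 3 `O=C(O)c1ccc(CN2CCC[C@H](O[C@H](CO)c3cc(Cl)cc(Cl)c3)[C@@H]2c2ccccc2)cc1` — 11000 nM

All three were tested in an assay on isolated protein for activation of cGMP-dependent protein kinase 1 (Homo sapiens), read by ADP-Glo, with stated times of 120 min and 40 min; on this read-out lower numbers stand for an effect already at smaller amounts and higher numbers for an effect only at larger amounts of compound. Among them compound 1 stands at the highest number, that is, it needs the largest amount to show an effect. The nearest of the others is compound 3, whose value sits well beyond the scatter below it; compound 2 lies further away still. Compound 1 is thus the weakest of the three on this read-out.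

The unmeasured compound 4 `Clc1cc(Cl)cc(CO[C@H]2CCCN(Cc3nccs3)[C@H]2c2ccccc2)c1` keeps the shared core of compound 1 and alters one group: 1,3-thiazol-2-yl in place of 1-methyl-1H-pyrazol-4-yl on a saturated chain carbon bound to an amine nitrogen in a ring. For the measured compounds named here, no measured pair shows this exact exchange, so no step size is known from the data for it.

Both groups are small five-membered aromatic rings with the same count of hydrogen-bond acceptors and no charge, so the change is a modest one. For compound 4 the expectation is a small shift, a 1.4-fold lower number from compound 1 to compound 4 (0.14 log units; within the scatter), leaning toward a slightly lower number but not clearly beyond the scatter. The estimate for compound 4 in this assay is 80000 nM, within a range from 30000 nM to 250000 nM.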

Compound 4, half-maximal effective concentration: > 200000 nM
Compound 4 gave a limit, no number; the forecaster's own chance of this, stated with the estimate: 15%; middle value at least 2.5-fold (0.39 log units) away from the limit.
By their numbers in this assay, from the lowest: compound 2; then compound 3; then compound 1. At a limit, above all of these: compound 4.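

In this assay compound 4 gives a limit and not a number: the limit of > 200000 nM in this assay, at which 1 of the 4 values shown sits.

Read as a step, this is an at least 1.8-fold higher number from compound 1 to compound 4 (0.25 log units; that floor lies within the scatter). The true gap may be larger, but this floor does not show a change beyond the usual scatter. For the compounds shown here, it is still the first step with only one change, made on a saturated chain carbon bound to an amine nitrogen in a ring, and it brings no lower number, although the two rings share the same counts of hydrogen-bond donors and acceptors and neither carries a net charge, so matching those counts did not bring a lower number here.

From the compounds shown here alone, the size of the gap stays unknown, since a limit cannot show whether compound 4 lies beyond the scatter from compound 1. Also open, going by these compounds, is how the number on the core of compound 1 would respond if a pyridine ring, a primary amide or a primary amine stood in place of the 1-methyl-1H-pyrazol-4-yl, which would show whether this place tolerates any exchange at all.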